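A few compounds are considered here, and "the series" means these few. Any claim that something is new, unique, unknown or untested is made for them only; others in the source may bear on it.

Of the compounds shown here, three built on one shared core have been measured in a functional assay on LOX IMVI cells (Homo sapiens) for antiproliferative activity, read by sulforhodamine B assay, with a stated time of 48 h; on this read-out lower numbers stand for stronger inhibition and higher numbers for weaker inhibition. Compound 1 `COc1cc(-c2nn(-c3ccc(NC(=O)c4ccc(Cl)c(Cl)c4)cc3)cc2-c2ccncc2)ccc1Cl` gives 2760 nM, compound 2 `COc1cc(-c2nn(-c3ccc(NC(=O)c4cc(Cl)cc(Cl)c4)cc3)cc2-c2ccncc2)ccc1Cl` gives 3090 nM, and compound 3 `COc1cc(-c2nn(-c3ccc(NC(=O)c4ccc(Cl)c(C(F)(F)F)c4)cc3)cc2-c2ccncc2)ccc1Cl` gives 1560 nM. On these numbers compound 3 sits at the low end, yet the steps of a 1.8-fold lower number from compound 1 to compound 3 (0.25 log units; within the scatter) and a 2.0-fold lower number from compound 2 to compound 3 (0.30 log units; within the scatter) are both within the scatter, as is a 1.1-fold higher number from compound 1 to compound 2 (0.05 log units; within the scatter). Compound 4 `O=C(Nc1ccc(-n2cc(-c3ccncc3)c(-c3ccc(Cl)c(O)c3)n2)cc1)c1ccc(Cl)c(C(F)(F)F)c1` differs from compound 3 by hydrogen in place of methyl on an oxygen on an aromatic ring. All three measured steps alter the group on the carbonyl carbon; none touches this oxygen, so they give no guide to the size of this change. Compound 4 is therefore expected to give 1800 nM, in a range from 600 nM to 6000 nM, an estimated step of a 1.2-fold higher number from compound 3 to compound 4 (0.06 log units; within the scatter).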

Compound 4, half-maximal inhibitory concentration: 360 nM
The estimate for compound 4 lay 5.0-fold (0.70 log units) above the measured number, and the stated range ends above it.
By their numbers in this assay, from the lowest: compound 4; then compounds 3, 1 and 2 (each within the scatter of the next).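

Swapping methoxy for hydroxy gives a 4.3-fold lower number from compound 3 to compound 4 (0.64 log units; beyond the scatter) in this assay and is the only step in this set that lies beyond the scatter. The earlier changes to the group on the carbonyl carbon all stayed within it, so this oxygen is the first place shown where a single change clearly moves the number. No measurement available here accounts for this shift.

As far as these compounds go, it remains open whether an amine or an ethoxy group in the same place would give a similar number. Going by these compounds alone, the hydroxy form also appears with only one group on the carbonyl carbon, so whether the step carries over to the dichlorophenyl compounds is unknown.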